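The source may report more compounds than this note shows. Statements on the series, on what has been measured and on what is new or still open speak of the compounds shown alone.

Measured so far in a functional assay on UACC-62 cells (Homo sapiens) for inhibition, read by sulforhodamine B assay, with a stated time of 48 h, tested at 10 uM; a lower number here means less inhibition, a higher number more inhibition at the concentration tested (going by the name of the read-out):
- compound 1 `c1ccc(-c2cn3ccnc3c(-c3ccc4ncn(C5CCCCC5)c4c3)n2)cc1` gives 65.7%
- compound 2 `c1cn2cc(-c3ccsc3)nc(-c3ccc4ncn(C5CCCCC5)c4c3)c2n1` gives 18.4%

Among the measured compounds shown here, compound 2 stands lowest of the two numbers; its nearest neighbour is compound 1, and the one measured step runs a number 47.3 percentage points lower from compound 1 to compound 2 (beyond the scatter), a large drop beyond the scatter, for thiophen-3-yl in place of phenyl on an aromatic carbon.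

Compound 3 `c1csc(-c2cn3ccnc3c(-c3ccc4ncn(C5CCCCC5)c4c3)n2)c1` is not yet measured. It differs from compound 2 by thiophen-2-yl in place of thiophen-3-yl on an aromatic carbon; the two have the same atoms, joined differently.

For the measured compounds named here, no measured step concerns this change: the single step from compound 1 to compound 2 bears on the exchange of phenyl for a thiophene, not on which carbon of the thiophene carries the attachment. The step is therefore expected to stay within the scatter in this assay, a number 5.6 percentage points higher from compound 2 to compound 3 (within the scatter), with compound 2 as the anchor. Compound 3 is estimated at 24%, range 5% to 50%.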

Compound 3, a percentage reported as inhibition, at one concentration (the size of the read-out at that concentration, not a potency): 24.8%
Estimate against measurement, compound 3: 0.8 percentage points below; measured number inside the range.
By their numbers in this assay, from the lowest: compounds 2 and 3 (each within the scatter of the next); then compound 1.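

In this assay, moving the thiophene attachment gives a number 6.4 percentage points higher from compound 2 to compound 3 (within the scatter) and so leaves thiophen-2-yl and thiophen-3-yl indistinguishable on this aromatic carbon next to the ring nitrogen. Phenyl to thiophen-2-yl gives a number 40.9 percentage points lower from compound 1 to compound 3 (beyond the scatter) and thus shows that the large loss in a number 47.3 percentage points lower from compound 1 to compound 2 (beyond the scatter) recurs with both thiophene attachments, so it does not depend on which thiophene carbon carries the bond. Nothing available accounts for the gap between phenyl and the two thiophenes.

Open, on these data alone, is whether the loss is specific to thiophene or extends to other five-membered rings such as furan-2-yl, and whether six-membered groups such as pyridin-3-yl or 4-methoxyphenyl stay close to phenyl. Also open, as far as these compounds go, is whether the same gap persists when a piperidine replaces the cyclohexyl group on the shared core.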